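The compounds below may be only part of what the source reports. "The series", "measured", "known", "first", "only" and "open" are said of these compounds alone.

Of the compounds shown here, three sharing one core have been measured in an assay on isolated protein for inhibition of aldehyde dehydrogenase 1A1 (Homo sapiens), tested at 5 uM; on this read-out lower numbers stand for less inhibition and higher numbers for more inhibition at the one concentration tested (going by the name of the read-out). Compound 1 `COCc1ccc(-n2c(SC(C)c3ccccc3)nc3c(cnn3C)c2=O)cc1` gives 65%, compound 2 `CC(Sc1nc2c(cnn2C)c(=O)n1-c1ccc(CN)cc1)c1ccccc1` gives 47%, and compound 3 `CC(Sc1nc2c(cnn2C)c(=O)n1-c1ccc(C#N)cc1)c1ccccc1` gives 55%. Compound 3 thus stands second highest of the three: its nearest neighbour is compound 2, with a number 8 percentage points higher from compound 2 to compound 3 (within the scatter), and its furthest is compound 1, with a number 10 percentage points lower from compound 1 to compound 3 (within the scatter), both within the scatter. The step to compound 4 `CNCc1ccc(-n2c(SC(C)c3ccccc3)nc3c(cnn3C)c2=O)cc1` is (methylamino)methyl in place of cyano on an aromatic carbon. Among the compounds with values here, two measured steps bear on it. The step of a number 8 percentage points higher from compound 2 to compound 3 (within the scatter) is close to the reverse of this swap, and a number 18 percentage points lower from compound 1 to compound 2 (beyond the scatter) shows that an amino-bearing chain in place of a methoxy-bearing one lowered the number beyond the scatter. Compound 4 carries a (methylamino)methyl group, which differs from the aminomethyl of compound 2 only by a methyl on the nitrogen, so a step of a number 5 percentage points lower from compound 3 to compound 4 (within the scatter) is expected, most likely a small decrease that need not exceed the scatter. Compound 4 is therefore estimated to give 50%, with a range from 35% to 65%.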

Compound 4, a percentage reported as inhibition, at one concentration (the size of the read-out at that concentration, not a potency): 58%
For compound 4 the middle estimate is 8 percentage points below the measured one; measured number inside the range.
By their numbers in this assay, from the lowest: compounds 2, 3, 4 and 1 (each within the scatter of the next, the first and the last beyond it).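

In this assay, methyl in place of hydrogen on the amine nitrogen gives a number 11 percentage points higher from compound 2 to compound 4 (beyond the scatter), so the two amine-bearing chains at this aromatic carbon do not read alike. The (methylamino)methyl group also cannot be told apart from the other two groups at this carbon: replacing cyano gives a number 3 percentage points higher from compound 3 to compound 4 (within the scatter), and replacing the methoxy of the methoxymethyl chain with methylamino gives a number 7 percentage points lower from compound 1 to compound 4 (within the scatter). No measured evidence is available to explain the difference that this single methyl makes.

The compounds shown leave open whether an ethyl or a second methyl on the same nitrogen would keep the number at this level. They also leave open how a carboxylic acid or a longer amine chain would read at this position.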